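A few compounds are considered here, and "the series" means these few. Any claim that something is new, unique, unknown or untested is made for them only; others in the source may bear on it.

In a physicochemical assay for solubility (on this read-out higher numbers stand for higher solubility and lower numbers for lower solubility), three related compounds have been read so far. Compound 1 (`Cc1nc(-c2cc(C(F)(F)F)ccc2[C@H]2CCOc3cc(S(=O)(=O)Nc4ncc(F)cn4)ccc32)co1`) gives 281000 nM and compound 2 (`O=C1OCCN1c1cc(C(F)(F)F)ccc1[C@H]1CCOc2cc(S(=O)(=O)Nc3nccs3)ccc21`) gives 295000 nM while compound 3 (`Cn1nccc1-c1cc(C(F)(F)F)ccc1[C@H]1CCc2cc(S(=O)(=O)Nc3ncccn3)ccc21`) gives 316000 nM in the same test. Compound 2 lies within the scatter of both others, so the three cannot be ranked. For the measured compounds named here, no two of them differ in one place only, and no measured step bears directly on the change that follows. Compound 4 (`O=S(=O)(Nc1nccs1)c1ccc2c(c1)OCC[C@@H]2c1ccc(C(F)(F)F)cc1N1CCNCC1`) carries piperazin-1-yl in place of 2-oxo-1,3-oxazolidin-3-yl on an aromatic carbon of compound 2 (piperazin-1-yl in place of 2-oxo-1,3-oxazolidin-3-yl on an aromatic carbon). The exchange lies ortho to a large group and meta to a trifluoromethyl group. Compound 1 at 281000 nM and compound 3 at 316000 nM differ from compound 2 at 295000 nM in several places and still stay within the scatter, so no shift beyond the scatter is expected in this assay here. The expected step is correspondingly small (a 1.0-fold higher number from compound 2 to compound 4 (0.01 log units; within the scatter)). For compound 4 the estimate is 300000 nM (expected range 100000 nM to 700000 nM).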

Compound 4, solubility: 288000 nM
Compound 4: middle estimate off by 1.0-fold (0.02 log units), on the high side; the range from low to high includes it.
By their numbers in this assay, from the lowest: compounds 1, 4, 2 and 3 (each within the scatter of the next).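

In this assay, for the compounds shown here, piperazin-1-yl in place of 2-oxo-1,3-oxazolidin-3-yl on this aromatic carbon, ortho to a large group and meta to a trifluoromethyl group, gives a 1.0-fold lower number from compound 2 to compound 4 (0.01 log units; within the scatter) as the first step in which only one place differs. At this position, therefore, a six-membered non-aromatic ring with 1 hydrogen-bond donor can replace a five-membered non-aromatic ring with 0 hydrogen-bond donors while the read-out stays within the scatter. Nothing measured here accounts for this result.

The compounds shown leave open whether a carboxylic acid or an open-chain amine on the same carbon would also stay within the scatter. They also leave open whether the same exchange would read alike on the core of compound 3.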